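The source may report more compounds than this note shows. Statements on the series, on what has been measured and on what is new or still open speak of the compounds shown alone.

The series is a pair of measured compounds and one awaiting measurement. Compound 1 `c1ccc(Sc2ncnc3[nH]cnc23)cc1` gives 0% in an assay on isolated protein for inhibition of RAC-alpha serine/threonine-protein kinase (Homo sapiens), tested at 30 uM; a higher number here means more inhibition at the concentration tested (going by the name of the read-out), a lower number less inhibition. Going by the values given here, compound 2 `Cn1cnc2c(Sc3ccccc3)ncnc21` gives 0% in this assay; the single step so far, no change at the digits printed from compound 1 to compound 2 (within the scatter), is methyl in place of hydrogen on an aromatic nitrogen and left the read-out where it was. Compound 2 therefore stands level with compound 1 on the numbers in hand, both without measurable inhibition at the concentration tested.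

Compound 3 `Cn1c(Br)nc2c(Sc3ccccc3)ncnc21` is the next step: bromo in place of hydrogen on an aromatic carbon. The bromo enters on an aromatic carbon of the five-membered aromatic ring with two nitrogen, between two ring nitrogen atoms, next to the ring atom that bears the methyl group. Among the compounds with values here, no measured step bears on this change directly; the only step available, no change at the digits printed from compound 1 to compound 2 (within the scatter), concerned another position and moved nothing, and neither measured compound shows any inhibition. Nothing in the data supports expecting the bromo to open up activity, so the expected step of a number 2 percentage points higher from compound 2 to compound 3 (within the scatter) is none beyond the scatter. Compound 3 is estimated at 2%, within a range of 0% to 15%.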

Compound 3, a percentage reported as inhibition, at one concentration (the size of the read-out at that concentration, not a potency): 1%
Beside the measured number, compound 3's estimate is 1 percentage points above it; low and high end bracket the measured number.
By their numbers in this assay, from the lowest: compounds 1, 2 and 3 (each within the scatter of the next).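

Bromo in place of hydrogen on an aromatic carbon of the five-membered aromatic ring with 2 nitrogen, between two ring nitrogen atoms and next to the ring atom that bears a methyl group, gives a number 1 percentage points higher from compound 2 to compound 3 (within the scatter) in this assay. Going by these compounds alone, this is the first reading at a ring carbon of the series, as the earlier step concerned an aromatic nitrogen, and it shows that a single bromine atom at this carbon does not separate compound 3 from compound 2 at the concentration tested. No further measurement bears on this result, so it stands as a bare reading with no account of it.

The compounds shown leave open whether a different group at this same carbon, such as an amine or a carboxylic acid, would give a read-out beyond the scatter of compound 2 in this assay. Also open, going by these compounds, is whether a longer chain in place of the methyl group, with the bromo kept, would give such a read-out.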